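The source may report more compounds than this note shows. Statements on the series, on what has been measured and on what is new or still open speak of the compounds shown alone.

Measured so far in a functional assay on the whole organism (6C3HED cells, Mus musculus) for inhibition, at a dose of 300 mg/kg by the oral route; on this read-out lower numbers stand for less inhibition and higher numbers for more inhibition at the one dose given (going by the name of the read-out):

compound 1, `O=C(Nc1ccc(Cl)cc1)NS(=O)(=O)c1ccc(Cl)s1`: 89%
compound 2, `CCc1csc(S(=O)(=O)NC(=O)Nc2ccc(Cl)cc2)c1`: 93%

Compound 2 stands at the upper of the two numbers, yet the step of a number 4 percentage points higher from compound 1 to compound 2 (within the scatter) lies within the scatter, so the two compounds are not separated on this read-out; both show strong inhibition at the one dose given.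

The next compound is compound 3, `Cc1cc(S(=O)(=O)NC(=O)Nc2ccc(Cl)cc2)sc1C`. Its difference from compound 2 is a group of 7 heavy atoms (6 carbon, 1 sulfur; one five-membered aromatic ring with 1 hetero atom) in place of a group of 7 heavy atoms (6 carbon, 1 sulfur; one five-membered aromatic ring with 1 hetero atom), on a sulfonyl sulfur.

Going by the values given here, the only measured step that bears on this change is a number 4 percentage points higher from compound 1 to compound 2 (within the scatter), which also altered the group on the sulfonyl sulfur and left the read-out within the scatter. The change to compound 3 keeps the same atoms in the group on the sulfonyl sulfur, joined differently, and there is no measured pair that tests such a rearrangement; the series therefore gives no reason to expect a step beyond the scatter in either direction.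

Compound 3 is expected to give about 90%, in the range 78% to 99%, which means an expected step of a number 3 percentage points lower from compound 2 to compound 3 (within the scatter), because the comparable change a number 4 percentage points higher from compound 1 to compound 2 (within the scatter) lay within the scatter.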

Compound 3, a percentage reported as inhibition, in the whole organism at one dose (the size of the read-out at that dose, not a potency): 73%
The estimate for compound 3 lay 17 percentage points above the measured number; the whole stated range lies above it.
By their numbers in this assay, from the lowest: compound 3; then compounds 1 and 2 (each within the scatter of the next).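

In this assay, the group on the sulfonyl sulfur is not interchangeable: with the same atoms joined differently, 4,5-dimethylthiophen-2-yl gives a number 20 percentage points lower from compound 2 to compound 3 (beyond the scatter) and so separates from a group that the earlier step of a number 4 percentage points higher from compound 1 to compound 2 (within the scatter) could not distinguish from 5-chlorothiophen-2-yl. Measured against 5-chlorothiophen-2-yl, the same group gives a number 16 percentage points lower from compound 1 to compound 3 (beyond the scatter) as a second modest step in the same direction, so the arrangement of the carbons in this group, and not only their number, goes with a difference in this read-out. Nothing at hand accounts for this difference.

The three compounds leave open whether the lower number goes with the 4,5-dimethyl arrangement itself or would also appear with other groups at this place on the sulfonyl sulfur, such as a methoxy group or an amine on the five-membered ring. With one dose only, they also leave open whether the step reflects a shift in potency or only in the size of the read-out at that dose.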